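A few compounds are considered here, and "the series" means these few. Any claim that something is new, unique, unknown or untested is made for them only; others in the source may bear on it.

Values measured in a functional assay on A549 cells (Homo sapiens) for antiproliferative activity, read by MTT assay, with a stated time of 48 h; on this read-out higher numbers stand for weaker inhibition and lower numbers for stronger inhibition:

- compound 1 `COc1ccc(N(C)c2ccnc(Cl)n2)cc1OCCBr`: 4640 nM
- compound 2 `COc1ccc(N(C)c2ccnc(Cl)n2)cc1OCCCCBr`: 591 nM
- compound 3 `COc1ccc(N(C)c2ccnc(Cl)n2)cc1OCCCCCBr`: 9720 nM

Of these three, compound 3 has the highest number, 9720 nM, which makes it the weakest inhibitor so far. Compound 4 `COc1ccc(N(C)c2ccnc(Cl)n2)cc1OCCCCC[Se]C#N` keeps the chain of compound 3 but exchanges the bromine at its end: a group of 3 heavy atoms (1 carbon, 1 nitrogen, 1 selenium; no ring) in place of one bromine atom, on a saturated chain carbon, five bonds along the chain from an oxygen on an aromatic ring.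

Within the data shown here, no measured step makes this exchange. All three keep the bromine and alter the chain: a 7.9-fold lower number from compound 1 to compound 2 (0.89 log units; beyond the scatter), a 2.1-fold higher number from compound 1 to compound 3 (0.32 log units; beyond the scatter) and a 16-fold higher number from compound 2 to compound 3 (1.22 log units; beyond the scatter). Among the measured compounds shown here, they show only that the number in this assay can shift from modest to large amounts within this small set, so they give the size of a plausible step but not its direction. Compound 3 at 9720 nM sits at the top of the range seen so far, so a modest move towards lower numbers is expected, with real uncertainty. The estimated change is a 4.9-fold lower number from compound 3 to compound 4 (0.69 log units; beyond the scatter). For compound 4 the estimated value is 2000 nM, with an expected range from 350 nM to 10000 nM.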

Compound 4, half-maximal inhibitory concentration: > 10000 nM
Compound 4: only a limit was reported; the forecaster's own chance of this, stated with the estimate: 3%; middle value at least 5.0-fold (0.69 log units) from the limit.
By their numbers in this assay, from the lowest: compound 2; then compound 1; then compound 3. At a limit, above all of these: compound 4.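

Compound 4 gives only a limit in this assay, > 10000 nM, so its result is a boundary and not a number: the limit of > 10000 nM in this assay, at which 1 of the 4 values shown sits. Exchanging bromo for the group of carbon, nitrogen and selenium on this chain gives an at least 1.0-fold higher number from compound 3 to compound 4 (0.01 log units; that floor lies within the scatter), so the exchange brings no measurable gain in inhibition, and whether compound 4 truly differs from its bromo partner cannot be said. The bromo compounds with shorter chains stand clearly apart, with an at least 16-fold higher number from compound 2 to compound 4 (1.22 log units; beyond the scatter) and an at least 2.1-fold higher number from compound 1 to compound 4 (0.33 log units; beyond the scatter).

As far as these compounds go, it remains open whether the same group would behave differently on the chain of compound 2, which has the lowest number. Also open, from the compounds shown here alone, is how other groups at this chain end, such as an amine or a carboxylic acid, would fare.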